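Compound 4: a ring-bearing group on the amine nitrogen

The source may report more compounds than this note shows. Statements on the series, on what has been measured and on what is new or still open speak of the compounds shown alone.

Measured in a functional assay on HepG2 cells (Homo sapiens) for inhibition, read by MTT assay, with a stated time of 48 h; on this read-out lower numbers stand for stronger inhibition and higher numbers for weaker inhibition (compound, structure, value)
compound 1 `CCOC(=O)C1=C(N/C=N/c2cccnc2Cl)Nc2[nH]nc(C)c2C1c1ccc(N(C)C)cc1` gives 4890 nM
compound 2 `CCOC(=O)C1=C(N/N=C(/C#N)C(=O)OCC)Nc2[nH]nc(C)c2C1c1ccc(N(C)C)cc1` gives 46400 nM
compound 3 `CCOC(=O)C1=C(N/N=C(\C#N)C(N)=O)Nc2[nH]nc(C)c2C1c1ccc(N(C)C)cc1` gives 48400 nM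

Compound 3 stands at the high end of the numbers, not separated from compound 2 (46400 nM) and well over compound 1 (4890 nM). Compound 4 `CCOC(=O)C1=C(N/N=C(/C(=O)Br)c2ccc(Br)cc2)Nc2[nH]nc(C)c2C1c1ccc(N(C)C)cc1` differs from compound 3 by a group of 12 heavy atoms (8 carbon, 1 nitrogen, 1 oxygen, 2 bromine; one six-membered aromatic ring of carbon only) in place of a group of 7 heavy atoms (3 carbon, 3 nitrogen, 1 oxygen; no ring), on an amine nitrogen at that nitrogen. Swapping between the two ring-free groups moved nothing (a 1.0-fold higher number from compound 2 to compound 3 (0.02 log units; within the scatter)). Leaving the ring-bearing group of compound 1 gave the only large moves (a 9.5-fold higher number from compound 1 to compound 2 (0.98 log units; beyond the scatter) and a 9.9-fold higher number from compound 1 to compound 3 (1.00 log units; beyond the scatter)). The group entering here also holds a six-membered aromatic ring, though it otherwise differs from that of compound 1, so a partial return towards lower numbers in this assay is expected. The expected change is a 3.5-fold lower number from compound 3 to compound 4 (0.54 log units; beyond the scatter) overall. For compound 4 the estimated value is 14000 nM (range 4000 nM to 50000 nM).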

Compound 4, half-maximal inhibitory concentration: 65000 nM
Estimate against measurement, compound 4: 4.6-fold (0.67 log units) below; the whole stated range lies below it.
By their numbers in this assay, from the lowest: compound 1; then compounds 2, 3 and 4 (each within the scatter of the next).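

In this assay, a six-membered aromatic ring of carbon only in the group on the amine nitrogen does not bring back the lower number of compound 1: a 1.3-fold higher number from compound 3 to compound 4 (0.13 log units; within the scatter) and a 1.4-fold higher number from compound 2 to compound 4 (0.15 log units; within the scatter) are both within the scatter, while a 13-fold higher number from compound 1 to compound 4 (1.12 log units; beyond the scatter) lies beyond it. A ring in this group is thus not enough on its own at this nitrogen. No measurement shown bears on why.

Open, going by these compounds, is which feature of the group of compound 1 goes with its lower number: the ring nitrogen, the chlorine or the link to the ring. A pyridine ring without chlorine or an unsubstituted phenyl ring on that same link would separate these.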